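Two inactive sulfonamide thiazolidinones and a chloro analogue

The compounds below may be only part of what the source reports. "The series", "measured", "known", "first", "only" and "open" are said of these compounds alone.

Compound 1 `NS(=O)(=O)c1cccc(/N=C2\NC(=O)/C(=C3/C(=O)Nc4ccc(Cl)cc43)S2)c1`: > 200000 nM in a functional assay on MCF7 cells (Homo sapiens) for antiproliferative activity, read by MTT assay (on this read-out lower numbers stand for stronger inhibition and higher numbers for weaker inhibition), a limit of the assay.
Compound 2 `NS(=O)(=O)c1ccc(/N=C2\NC(=O)/C(=C3/C(=O)N(Cc4ccccc4)c4ccccc43)S2)cc1`: > 200000 nM in this assay, also a limit of the assay.

Neither measured compound yields a number. Compound 2 sits at the limit of > 200000 nM in this assay, at which 2 of the 2 values shown sit, so no inhibition could be resolved for it in this assay. Among the compounds with values here, compound 1 sits at the same ceiling, and no step between the two measured compounds can be drawn, since they differ in more than one place.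

Compound 3 `NS(=O)(=O)c1ccc(/N=C2\NC(=O)/C(=C3/C(=O)N(Cc4ccccc4)c4ccc(Cl)cc43)S2)cc1` differs from compound 2 by chloro in place of hydrogen on an aromatic carbon. Within the data shown here, no measured step covers such a change here, and compound 1, which also carries chloro on that ring, gives no number either. For that reason compound 3 is expected to remain at or beyond the ceiling of this assay, with a step that the limit leaves unreadable from compound 2 to compound 3, none beyond the scatter. The estimate for compound 3 is 300000 nM, with a range from 100000 nM to 1000000 nM.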

Compound 3, half-maximal inhibitory concentration: 124000 nM
Compound 3: the middle estimate sits 2.4-fold (0.38 log units) above what was measured; low and high end bracket the measured number.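

In this assay, within the data shown here, compound 3 gives 124000 nM, the first true number, with chloro in place of hydrogen on this aromatic carbon. The change reads as an at least 1.6-fold lower number from compound 2 to compound 3 (0.20 log units; that floor lies within the scatter). On these data alone, that figure is only a floor, and the full size of the step stays unknown because compound 2 has no number of its own: the limit of > 200000 nM in this assay, at which 2 of the 3 values shown sit.

Among these compounds, compound 1 remains at a limit of the assay, > 200000 nM, and it differs from compound 3 in more than one place, so no step to it can be read. As far as these compounds go, whether bromo, methoxy or an amine on this same carbon would move the read-out further, or less far, than chloro remains open.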